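This account rests on a few compounds, and the source may have more. Where it says the series, first, only, none or still open, it means among the compounds named here.

The study follows three measured compounds that share one core and differ only in the group attached on a carbon with a double bond to nitrogen. Compound 1 `O=C(N/N=C/c1cccc(Br)c1)Nc1ccc(Oc2ccnc3[nH]ccc23)c(F)c1` carries a 3-bromophenyl there, while compound 2 `COc1ccc(/C=N/NC(=O)Nc2ccc(Oc3ccnc4[nH]ccc34)c(F)c2)c(OC)c1OC` and compound 3 `CC(C)(C)c1cc(/C=N/NC(=O)Nc2ccc(Oc3ccnc4[nH]ccc34)c(F)c2)cc(C(C)(C)C)c1O` carry other groups in that place. In a functional assay on HepG2 cells (Homo sapiens) for antiproliferative activity, read by MTT assay, with a stated time of 72 h (on this read-out higher numbers stand for weaker inhibition and lower numbers for stronger inhibition), compound 1 gives 660 nM, the lowest of the three numbers. Compound 2 gives 2990 nM and compound 3 gives 7220 nM, both beyond the scatter from compound 1, so among these three compound 1 is the strongest inhibitor.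

Compound 4 `CN(C)CCn1cccc1/C=N/NC(=O)Nc1ccc(Oc2ccnc3[nH]ccc23)c(F)c1` has not yet been measured. It differs from compound 1 in one place: 1-(2-(dimethylamino)ethyl)-1H-pyrrol-2-yl in place of 3-bromophenyl on a carbon with a double bond to nitrogen. Within the data shown here, no step between two measured compounds isolates such a change, so the expectation rests only on the three values shown, where compound 2 and compound 3, each with another group at the same place, gave higher numbers than compound 1. Compound 4 is therefore expected to come out somewhat weaker than compound 1, although a number within the scatter of compound 1 would not surprise. The expected step is a 2.3-fold higher number from compound 1 to compound 4 (0.36 log units; beyond the scatter). The estimate for compound 4 in this assay is 1500 nM, with a range from 400 nM to 6000 nM.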

Compound 4, half-maximal inhibitory concentration: 8980 nM
Estimate against measurement, compound 4: 6.0-fold (0.78 log units) below, outside the stated range (above it).
By their numbers in this assay, from the lowest: compound 1; then compound 2; then compounds 3 and 4 (each within the scatter of the next).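

In this assay, replacing the 3-bromophenyl gives a 14-fold higher number from compound 1 to compound 4 (1.13 log units; beyond the scatter), a large step that shows this place on a carbon with a double bond to nitrogen can cost far more activity than the opening values alone suggested. The loss is not confined to groups built on a six-membered aromatic ring of carbon only, as in compound 2 and compound 3: a five-membered aromatic ring with 1 hetero atom, carrying its 2-(dimethylamino)ethyl chain, also gives a higher number than compound 1, and compound 4 at 8980 nM lies within the scatter of compound 3 at 7220 nM. Nothing measured here accounts for the size of this step.

The new ring and the chain enter together, so the compounds shown cannot tell which of them carries the loss; a 1-methyl-1H-pyrrol-2-yl group, or a phenyl ring bearing the same 2-(dimethylamino)ethyl chain, would separate the two. Also open, as far as these compounds go, is how a shorter chain, a morpholine in place of the dimethylamino group, or an unsubstituted phenyl would compare with compound 1.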